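Swapping the hydroxymethyl of compound 3 for phenyl

This account rests on a few compounds, and the source may have more. Where it says the series, first, only, none or still open, it means among the compounds named here.

Compound 3 `N=C(NCCO)N1C[C@H](O)[C@@H](O)[C@H](O)[C@H]1CO` gives 540000 nM in an assay on isolated protein for inhibition of alpha-galactosidase (Coffea arabica), read by spectrophotometry, with a stated time of 30 min (a lower number here means a stronger inhibitor, a higher number a weaker inhibitor), the highest number among the values that are numbers. Compound 1 `CCCCCCCCNC(=N)N1C[C@H](O)[C@@H](O)[C@H](O)[C@H]1CO` gives 23000 nM. Compound 2 `N=C(NCCOCCO)N1C[C@H](O)[C@@H](O)[C@H](O)[C@H]1CO` reaches only the limit > 1000000 nM, a limit and not a number (the limit of > 1000000 nM in this assay, at which 1 of the 3 values shown sits). Compound 4 `N=C(NCc1ccccc1)N1C[C@H](O)[C@@H](O)[C@H](O)[C@H]1CO` differs from compound 3 by phenyl in place of hydroxymethyl on a saturated chain carbon bound to an amine nitrogen. Within the data shown here, the steps that bear on it are a 23-fold higher number from compound 1 to compound 3 (1.37 log units; beyond the scatter) and an at least 43-fold higher number from compound 1 to compound 2 (1.63 log units; beyond the scatter), both showing that replacing a lipophilic chain by a hydroxylated one raises the number strongly; the step of an at least 1.8-fold lower number from compound 2 to compound 3 (0.26 log units; that floor lies within the scatter) adds little. Compound 4 moves in the opposite direction, toward a non-polar group, so a lower number beyond the scatter is expected, though phenyl is not hexyl. For compound 4 the expected step is a 5.4-fold lower number from compound 3 to compound 4 (0.73 log units; beyond the scatter). Compound 4 is therefore estimated at 100000 nM, between 20000 nM and 600000 nM.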

Compound 4, half-maximal inhibitory concentration: > 1000000 nM
Compound 4: only a limit was reported; the forecaster's own chance of this, stated with the estimate: 10%; middle value at least 10-fold (1.00 log units) away from the limit.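

In this assay compound 4 reaches only a limit, > 1000000 nM, not a number: the limit of > 1000000 nM in this assay, at which 2 of the 4 values shown sit.

Phenyl at this place does not stand in for heptyl, with an at least 43-fold higher number from compound 1 to compound 4 (1.63 log units; beyond the scatter). Against hydroxymethyl the result is an at least 1.8-fold higher number from compound 3 to compound 4 (0.26 log units; that floor lies within the scatter), so an aromatic ring of carbon only brings no lower number here, and the step between the two limits cannot be read.

On these data alone, whether a butyl chain would keep part of the lower number of compound 1 stays open. So does the effect of a phenyl set further out, as in a 4-phenylbutyl chain.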